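Nitro for cyano on the benzyl ether of a constrained glutamate analogue

The source may hold more compounds than are shown below. What is called first, only, known or untested is meant among the compounds shown, and "the series" means these compounds.

Compound 1, `N[C@]1(C(=O)O)[C@H]2[C@@H](C[C@H]1OCc1cccc(Cl)c1)[C@]2(F)C(=O)O`, gives 3.28 nM in an assay on CHO cells for binding affinity to metabotropic glutamate receptor 2 (Rattus norvegicus); on this read-out higher numbers stand for weaker inhibition and lower numbers for stronger inhibition.
Compound 2, `N[C@]1(C(=O)O)[C@H]2[C@@H](C[C@H]1OCc1cccc(Br)c1)[C@]2(F)C(=O)O`, gives 4.71 nM in this assay.
Compound 3, `N#Cc1cccc(CO[C@@H]2C[C@@H]3[C@H]([C@]2(N)C(=O)O)[C@@]3(F)C(=O)O)c1`, gives 2.94 nM in this assay.

Compound 3 has the lowest of the three numbers, yet its distances to the others are small: a 1.1-fold lower number from compound 1 to compound 3 (0.05 log units; within the scatter) and a 1.6-fold lower number from compound 2 to compound 3 (0.20 log units; within the scatter), both within the scatter, so no order among the three can be claimed. Compound 4, `N[C@]1(C(=O)O)[C@H]2[C@@H](C[C@H]1OCc1cccc([N+](=O)[O-])c1)[C@]2(F)C(=O)O`, is the next member: nitro in place of cyano on an aromatic carbon, the change sitting on an aromatic carbon of the six-membered aromatic ring of carbon only, meta to a large group.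

Among the compounds with values here, the steps that bear on this change are the three swaps at the same aromatic carbon, chloro to bromo (a 1.4-fold higher number from compound 1 to compound 2 (0.16 log units; within the scatter)), chloro to cyano and bromo to cyano. Each lies within the scatter, which shows that this position has so far tolerated groups of different size without a shift in the inhibition constant. A nitro group is a further substituent of comparable scope, and on the evidence at hand no step beyond the scatter is expected in this assay, in either direction.

Compound 4 is therefore estimated at 4 nM, with a range from 1.5 nM to 11 nM, the expected step being a 1.4-fold higher number from compound 3 to compound 4 (0.13 log units; within the scatter).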

Compound 4, inhibition constant: 7.87 nM
Compound 4: middle estimate off by 2.0-fold (0.29 log units), on the low side, and the stated range covers the measured number.
By their numbers in this assay, from the lowest: compounds 3, 1, 2 and 4 (each within the scatter of the next, the first and the last beyond it).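

In this assay, within the data shown here, this aromatic carbon no longer looks indifferent to its substituent: nitro in place of cyano gives the first steps beyond the scatter at this place, (a 2.7-fold higher number from compound 3 to compound 4 (0.43 log units; beyond the scatter)) and, for nitro in place of chloro, (a 2.4-fold higher number from compound 1 to compound 4 (0.38 log units; beyond the scatter)), both of them modest. Nitro in place of bromo stays within the scatter (a 1.7-fold higher number from compound 2 to compound 4 (0.22 log units; within the scatter)), so the nitro compound stands apart from the cyano and chloro compounds but not from the bromo compound, and the three groups seen earlier remain within the scatter of one another. Nothing measured here accounts for these steps.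

What stays open is whether such steps are particular to nitro or would also appear with other groups on this carbon, for the compounds shown carry only chloro, bromo, cyano and nitro there, leaving an amine, a carboxylic acid, a methoxy group or a longer chain unplaced. Also open is whether the same swaps would read alike on another carbon of the aromatic ring, as every group shown here sits in the one place, meta to a large group.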